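This account rests on a few compounds, and the source may have more. Where it says the series, first, only, none or still open, it means among the compounds named here.

Measured compounds:
compound 1, `Cc1c(NC(=O)C(Sc2ccc3ccccc3c2)C(C)C)ccc2nc(N)nc(N)c12`, 7.68
compound 2, `CC(C(=O)Nc1ccc2nc(N)nc(N)c2c1Cl)c1ccccc1`, 7.77
compound 3, `Nc1ncnc2ccc(Sc3ccc4ccccc4c3)cc12`, 4.68

In an assay for inhibition of Dihydrofolate reductase (Homo sapiens) (a lower number here means a less potent compound, a higher number a more potent compound, by a factor of ten per unit of this negative logarithm), compound 1 gives 7.68, the second highest of the three numbers. Compound 2 gives 7.77 in this assay, and the two values sit within the usual scatter of each other, so nothing separates them. Compound 3 stands far apart: in this assay compound 3 gives 4.68, a number well below that of compound 1 and beyond the scatter, and it also lacks the amide-linked side chain and carries a different core.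

The unmeasured compound 4, `Cc1c(NC(=O)CSc2ccc3ccccc3c2)ccc2nc(N)nc(N)c12`, differs from compound 1 in one place: hydrogen in place of isopropyl on a saturated chain carbon bound to a carbonyl carbon and a sulfur. Going by the values given here, no step between two measured compounds isolates this kind of change, so any expectation rests on compound 1 alone and on the observation that compound 2, with a differently built side chain, lands in the same range. A small step downward or none beyond the scatter is expected; the step from compound 1 to compound 4 is estimated as a number 0.28 log units lower from compound 1 to compound 4 (within the scatter). For compound 4 in this assay a value of 7.4 is expected, within a range of 6.8 to 8.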

Compound 4, logarithm of the reciprocal of the active concentration, log(1/C): 8.27
Estimate against measurement, compound 4: 0.87 log units below, and the stated range ends below it.
By their numbers in this assay, from the lowest: compound 3; then compounds 1 and 2 (each within the scatter of the next); then compound 4.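

With hydrogen in place of isopropyl on the saturated chain carbon bound to a carbonyl carbon and a sulfur, this assay records a number 0.59 log units higher from compound 1 to compound 4 (beyond the scatter). Going by these compounds alone, no earlier pair differed in one place, so this is the first sign that the number responds to what sits at this position, and it shows that the isopropyl group is not needed for a high value: in this pair, the compound without it has the higher number. The compounds shown offer no independent information on why the number rises with this change.

Going by these compounds, a single pair gives only two points at this position, so it remains open whether the number would rise or fall steadily with the size of the group or whether the unsubstituted chain carbon is a special case; a methyl group or an ethyl group at the same place would lie between the two points. Also open, on these data alone, is how the position would respond to a group of a different kind, such as an amine, a hydroxyl group or a carboxylic acid, in place of the hydrogen of compound 4.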